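Butenyl chain on the benzyl ether series: compound 2 to 4

The source may hold more compounds than are shown below. What is called first, only, known or untested is meant among the compounds shown, and "the series" means these compounds.

compound 1 `COc1ccc(/C=C\c2cc(OC)c(OC)c(OC)c2)cc1OCc1ccccc1`: 15000 nM
compound 2 `COc1ccc(/C=C\c2cc(OC)c(OC)c(OC)c2)cc1OCc1ccc(Br)cc1`: 45000 nM
compound 3 `COCOc1ccc(/C=C/CCCOc2cc(/C=C\c3cc(OC)c(OC)c(OC)c3)ccc2OC)cc1`: 25000 nM

Not yet measured: compound 4 `COc1ccc(/C=C\c2cc(OC)c(OC)c(OC)c2)cc1OCCC/C=C/c1ccc(Cl)cc1`.

In an ADME assay on HEK293 cells (Homo sapiens) for inhibition, read by MTT assay, with a stated time of 3 days (a higher number here means a weaker inhibitor, a lower number a stronger inhibitor), compound 2 at 45000 nM sits within the scatter of compound 3 at 25000 nM. Among the compounds with values here, the one measured step is modest: a 3.0-fold higher number from compound 1 to compound 2 (0.48 log units; beyond the scatter). Going on to compound 4, 4-(4-chlorophenyl)but-3-en-1-yl replaces 4-bromophenyl on a saturated chain carbon bound to an oxygen on an aromatic ring (4-(4-chlorophenyl)but-3-en-1-yl in place of 4-bromophenyl on a saturated chain carbon bound to an oxygen on an aromatic ring). Within the data shown here, no measured step covers this exchange directly. The nearest guide is compound 3 at 25000 nM, which also carries a but-3-en-1-yl chain, so no step beyond the scatter is expected. The expected step is a 1.8-fold lower number from compound 2 to compound 4 (0.26 log units; within the scatter). For compound 4 the estimate is 25000 nM, with an expected range of 10000 nM to 60000 nM.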

Compound 4, half-maximal inhibitory concentration: 111000 nM
Compound 4: the middle estimate sits 4.4-fold (0.65 log units) below what was measured; the whole stated range lies below it.
By their numbers in this assay, from the lowest: compounds 1, 3 and 2 (each within the scatter of the next, the first and the last beyond it); then compound 4.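

In this assay the 4-(4-chlorophenyl)but-3-en-1-yl chain on this ether oxygen makes compound 4 the weakest inhibitor shown, with a 2.5-fold higher number from compound 2 to compound 4 (0.39 log units; beyond the scatter) and a 7.4-fold higher number from compound 1 to compound 4 (0.87 log units; beyond the scatter). With the butenyl chain present in both compounds, chloro in place of methoxymethoxy on an aromatic carbon gives a 4.4-fold higher number from compound 3 to compound 4 (0.65 log units; beyond the scatter), so the chain alone does not fix the number. No measurement available here explains these steps.

Still open, going by these compounds, is how the butenyl chain behaves with an unsubstituted phenyl group. Also open, on these data alone, is whether a chain carrying an amine or a carboxylic acid would move the number in either direction.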